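Furan-2-yl in Place of Phenyl on the Benzoyl Amide

The source may report more compounds than this note shows. Statements on the series, on what has been measured and on what is new or still open speak of the compounds shown alone.

Compound 1 `CCCCCCCCCCCCCCCCCCNC(=O)[C@@H](N)[C@@H](C)O`: 39500 nM
Compound 2 `CCCCCCCCNC(=O)[C@@H](NC(=O)c1ccccc1)[C@@H](C)O`: 112000 nM

Of the compounds shown here, two have been measured in a functional assay on SiHa cells (Homo sapiens) for cytotoxicity, read by MTT assay, with a stated time of 48 h; a lower number here means a stronger inhibitor, a higher number a weaker inhibitor. Compound 1 gives 39500 nM in this assay, and compound 2 gives 112000 nM. Compound 2 therefore stands at the highest number of the two, and the gap between compound 2 and compound 1 goes beyond the usual scatter. Going by the values given here, no pair among the measured compounds differs in only one place, so no single-change step is available to guide the next comparison.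

Compound 3 `CCCCCCCCNC(=O)[C@@H](NC(=O)c1ccco1)[C@@H](C)O` differs from compound 2 in one place: furan-2-yl in place of phenyl on a carbonyl carbon. With no measured step of this kind in the series, the expectation rests on the small size of the change, which leaves the rest of the molecule untouched. The step of a 1.1-fold lower number from compound 2 to compound 3 (0.05 log units; within the scatter) is expected to be small, with no direction that can be told apart from the scatter. Compound 3 is accordingly estimated at 100000 nM, with a range from 40000 nM to 250000 nM.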

Compound 3, half-maximal inhibitory concentration: 124000 nM
Compound 3: the middle estimate sits 1.2-fold (0.09 log units) below what was measured; measured number inside the range.
By their numbers in this assay, from the lowest: compound 1; then compounds 2 and 3 (each within the scatter of the next).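

In this assay, the series now has its first single-change step, and replacing phenyl with furan-2-yl on a carbonyl carbon whose other neighbour is an amide-type nitrogen gives a 1.1-fold higher number from compound 2 to compound 3 (0.04 log units; within the scatter). At this position, then, a five-membered aromatic ring with one hetero atom and one hydrogen-bond acceptor stands in for a six-membered all-carbon aromatic ring without a difference that can be told apart from the scatter. No measurement is available that bears on why these two rings read alike here.

The compounds shown leave open whether a group of another kind on this carbonyl carbon, such as a pyridin-2-yl ring or an aminophenyl ring, would separate from phenyl and furan-2-yl in this assay. They also leave open what a longer chain alone would do in compound 2, as compound 1 differs from compound 2 in more than one place and its value cannot be assigned to either difference.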